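This account rests on a few compounds, and the source may have more. Where it says the series, first, only, none or still open, it means among the compounds named here.

Of the compounds shown here, two sharing one core have been measured in a functional assay on MDA-MB-231 cells (Homo sapiens) for antiproliferative activity, read by XTT assay, with a stated time of 72 h; a lower number here means a stronger inhibitor, a higher number a weaker inhibitor. Compound 1 `COc1ccc(-c2cc3ccccc3nc2/C=C/C(=O)c2ccc(OC)c(OC)c2)cc1` gives 4790 nM. Among the measured compounds shown here, compound 2 `COc1ccc(-c2cc3ccccc3nc2/C=C/C(=O)c2ccco2)cc1` gives 630 nM, the lowest of the two numbers, with compound 1 as its only neighbour. For the measured compounds named here, the one measured step, a 7.6-fold lower number from compound 1 to compound 2 (0.88 log units; beyond the scatter), came from putting furan-2-yl in place of 3,4-dimethoxyphenyl on the carbonyl carbon, a change beyond the usual scatter.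

Compound 3 `COc1ccc(-c2cc3ccccc3nc2/C=C/C(=O)c2ccc[nH]2)cc1` has not yet been measured. It differs from compound 2 in one place: 1H-pyrrol-2-yl in place of furan-2-yl on a carbonyl carbon. The change sits on the same carbonyl carbon as the measured step, but that step swapped a six-membered ring with two substituents for a bare five-membered one, whereas here the five-membered ring stays and only its hetero atom changes, trading one hydrogen-bond acceptor for one donor. Going by the values given here, no measured pair tests that exchange, so the step from compound 2 to compound 3 is expected to be small, a 1.3-fold higher number from compound 2 to compound 3 (0.10 log units; within the scatter), likely within the scatter. Compound 3 is therefore estimated at 800 nM, with a range from 250 nM to 2600 nM.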

Compound 3, half-maximal inhibitory concentration: > 10000 nM
Compound 3 ended at the assay's limit; the forecaster's own chance of this, stated with the estimate: 3%; at least 12-fold (1.09 log units) between middle value and limit.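

Among the compounds shown here, this position tolerates far less than the earlier compounds suggested. With the ring size and heavy-atom count unchanged on the carbonyl carbon, replacing furan-2-yl with 1H-pyrrol-2-yl, which exchanges the ring oxygen for a ring nitrogen bearing a hydrogen, gives an at least 15-fold higher number from compound 2 to compound 3 (1.20 log units; beyond the scatter). A bare five-membered aromatic ring is therefore not enough to secure the gain seen in a 7.6-fold lower number from compound 1 to compound 2 (0.88 log units; beyond the scatter), since the pyrrole ring also falls behind the 3,4-dimethoxyphenyl group, with an at least 2.0-fold higher number from compound 1 to compound 3 (0.31 log units; beyond the scatter). Compound 3 reads > 10000 nM in this assay, which is a limit of the assay and not a number: the limit of > 10000 nM in this assay, at which 1 of the 3 values shown sits.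

Going by these compounds, the true size of both new steps stays open, as does whether the loss tracks the missing ring oxygen, meaning the lost hydrogen-bond acceptor, or the added hydrogen on the ring nitrogen, meaning the new donor. A thiophen-2-yl group, with sulfur as its ring hetero atom, and a 1-methylpyrrol-2-yl group, which keeps the ring nitrogen but carries a methyl in place of its hydrogen, would help to separate these two readings.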